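Phenyl substitution in the shared core: inhibition so far

The source may report more compounds than this note shows. Statements on the series, on what has been measured and on what is new or still open speak of the compounds shown alone.

Measured compounds:
Compound 1, `CCC(COc1ccccc1Cl)OC(=O)NCc1ccccc1`: in an assay for inhibition of zeta-carotene desaturase, chloroplastic/chromoplastic (Capsicum annuum), using a Dixon plot, with a stated time of 8 h (on this read-out higher numbers stand for weaker inhibition and lower numbers for stronger inhibition), compound 1 gives only a limit, > 100000 nM.
Compound 2, `CCC(COc1cccc(Br)c1)OC(=O)NCc1ccccc1`: in this assay compound 2 gives only a limit, > 100000 nM.
Compound 3, `CCC(COc1cccc(OC)c1)OC(=O)NCc1ccccc1`: in this assay compound 3 gives only a limit, > 100000 nM.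

Compound 1 therefore has no number in this assay, only a limit, and the same holds for the two compounds with which it is compared; (the limit of > 100000 nM in this assay, at which 3 of the 3 values shown sit). The steps a step that the two limits leave unreadable from compound 1 to compound 2 and a step that the two limits leave unreadable from compound 1 to compound 3 are unreadable, and a step that the two limits leave unreadable from compound 2 to compound 3 is likewise unreadable.

Compound 4, `CCC(COc1cc(Cl)cc(Cl)c1)OC(=O)NCc1ccccc1`, differs from compound 1 in one place: 3,5-dichlorophenyl in place of 2-chlorophenyl on an oxygen on a saturated carbon. Going by the values given here, the steps that bear on this change give no readable size and no direction. No step beyond the scatter is expected, and compound 4 is expected to give a number no higher from compound 1 to compound 4 (the limit leaves the size open) in this assay. For compound 4 the estimate is 100000 nM, in the range 30000 nM to 300000 nM, most likely again reported only as a limit.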

Compound 4, half-maximal inhibitory concentration: > 100000 nM
Compound 4: only a limit was reported; the forecaster's own chance of this, stated with the estimate: 85%; the middle value sits exactly at the limit.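

Compound 4 also gives only a limit in this assay, so the steps to it from compound 1, compound 2 and compound 3 cannot be read: the limit of > 100000 nM in this assay, at which 4 of the 4 values shown sit.

On these data alone, whether any phenyl substitution on the shared core gives measurable inhibition remains open.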